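Chloro on the Fused Ring and Cell Tolerance

The source may report more compounds than this note shows. Statements on the series, on what has been measured and on what is new or still open speak of the compounds shown alone.

Three compounds have been measured in an ADME assay on THP-1 cells (Homo sapiens) for cytotoxicity, read by MTT assay, with a stated time of 72 h; a lower number here means that less compound is tolerated, a higher number that more compound is tolerated:

Compound 1 `O[C@@H]1Cc2cc(Cl)ccc2N[C@H](c2ccccc2)C1` gives 188000 nM.
Compound 2 `O[C@@H]1Cc2cc(Cl)ccc2N[C@H](c2ccc(Cl)cc2)C1` gives 49200 nM.
Compound 3 `O[C@@H]1Cc2ccccc2N[C@H](c2c(Cl)cccc2Cl)C1` gives only a limit of the assay, > 300000 nM.

Compound 2 differs from compound 1 by chloro in place of hydrogen on an aromatic carbon, and this change gave a 3.8-fold lower number from compound 1 to compound 2 (0.58 log units; beyond the scatter). Compound 4 `O[C@@H]1Cc2cc(Cl)ccc2N[C@H](c2c(Cl)cccc2Cl)C1` has not been measured; it differs from compound 3 by chloro in place of hydrogen on an aromatic carbon, the same kind of change, though the surroundings differ: in compound 2 the chloro sits para to a large group, in compound 4 meta to a fused ring and para to a fused ring. The difference between the cores of compound 1 and compound 3 is not broken down here.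

Compound 3 sits at the limit of > 300000 nM in this assay, at which 1 of the 3 values shown sits, so the size of its step to compound 4 cannot be read off directly. Resting on a 3.8-fold lower number from compound 1 to compound 2 (0.58 log units; beyond the scatter), a lower number than the limit is expected for compound 4. Compound 4 is expected to give about 150000 nM in this assay. The expected step is an at least 2.0-fold lower number from compound 3 to compound 4 (0.30 log units; that floor lies within the scatter).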

Compound 4, half-maximal cytotoxic concentration: 59600 nM
The estimate for compound 4 lay 2.5-fold (0.40 log units) above the measured number; low and high end bracket the measured number.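

In this assay, chloro in place of hydrogen on an aromatic carbon gave an at least 5.0-fold lower number from compound 3 to compound 4 (0.70 log units; beyond the scatter), so the direction of the earlier step, a 3.8-fold lower number from compound 1 to compound 2 (0.58 log units; beyond the scatter), held on a second core. Both steps lie beyond the scatter, though the added chloro does not stand in the same surroundings in the two pairs. What this does not show is whether the change lowers the number by the same amount on both cores: the same change on two cores in this assay, a 3.8-fold lower number (0.58 log units; beyond the scatter) from compound 1 to compound 2 and an at least 5.0-fold lower number (0.70 log units; beyond the scatter) from compound 3 to compound 4; the limit leaves it open whether they differ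

The compounds shown carry only chloro or hydrogen at these aromatic carbons, leaving open whether fluoro, methoxy or an amine there would shift the number the same way. Two pairs also cannot tell whether the lower number would recur on further cores.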